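Hydrazone series: dichloro analogue expected close to parent

A few compounds are considered here, and "the series" means these few. Any claim that something is new, unique, unknown or untested is made for them only; others in the source may bear on it.

Two members of the series have numbers in a functional assay on A549 cells (Homo sapiens) for cytotoxicity, read by XTT assay, with a stated time of 24 h; on this read-out higher numbers stand for weaker inhibition and lower numbers for stronger inhibition. Compound 1 `Cn1nnnc1SCC(=O)N/N=C/c1ccccc1[N+](=O)[O-]` gives 1600000 nM. Compound 2 `C/C(=N\NC(=O)CSc1nnnn1C)c1ccccc1Cl` gives 6320000 nM, the highest of the two numbers; its nearest neighbour is compound 1, whose number is lower by a margin beyond the usual scatter. Among the measured compounds shown here, these two differ in more than one place, so no single step between them is counted; their values stand on their own. Compound 3 `C/C(=N\NC(=O)CSc1nnnn1C)c1ccc(Cl)cc1Cl` is not yet measured in this assay. It differs from compound 2 by chloro in place of hydrogen on an aromatic carbon. For the measured compounds named here, no measured pair isolates such an exchange, so the size of the step has no precedent within these data. The expectation is a step of modest size, not confidently beyond the scatter, with a slight lean toward a lower number: the estimated step is a 1.6-fold lower number from compound 2 to compound 3 (0.20 log units; within the scatter). Compound 3 is accordingly estimated at 4000000 nM, with a range from 1500000 nM to 12000000 nM. Both measured numbers sit very high, so there is some chance that compound 3 returns only a limit.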

Compound 3, half-maximal inhibitory concentration: 800000 nM
Compound 3: the middle estimate sits 5.0-fold (0.70 log units) above what was measured; measured number outside the range, below it.
By their numbers in this assay, from the lowest: compounds 3 and 1 (each within the scatter of the next); then compound 2.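

Chloro in place of hydrogen on an aromatic carbon, para to a large group and meta to a chloro group, is the only exchange in the series that can be read on its own, and in this assay it gives a 7.9-fold lower number from compound 2 to compound 3 (0.90 log units; beyond the scatter) as the first measured step. This place on the ring therefore responds to substitution: one added heavy atom, with no ring, no hydrogen-bond donors or acceptors and no net charge, moves the number beyond the scatter toward stronger inhibition. Nothing available here accounts for the size of this step.

The compounds shown leave open whether the step belongs to chloro itself or would also appear with another group at this place, such as fluoro, methoxy or an amine. Also open, from the compounds shown here alone, is whether the same step would appear with the other chloro group removed, leaving the entering chloro alone on the ring.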